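Para-chloro on the aryl imine of compound 2

A few compounds are considered here, and "the series" means these few. Any claim that something is new, unique, unknown or untested is made for them only; others in the source may bear on it.

Measured so far:
- compound 1 `CC(=O)/C(=N\Nc1ccccc1C#N)Nc1cccc(Cl)c1`: 415 nM; 415 nM (2 entries)
- compound 2 `CC(=O)/C(=N\c1ccccc1)NNc1ccccc1C`: 526 nM

Compound 1 `CC(=O)/C(=N\Nc1ccccc1C#N)Nc1cccc(Cl)c1` gives 415 nM; 415 nM (2 entries) in an assay on isolated protein for binding affinity to corticotropin-releasing factor receptor 1 (Homo sapiens); a higher number here means a weaker inhibitor, a lower number a stronger inhibitor. Among the compounds with values here, compound 2 `CC(=O)/C(=N\c1ccccc1)NNc1ccccc1C` gives 526 nM in this assay; this is the only number for compound 2, and one further entry for it carries no single number. Within the data shown here, compounds 1 and 2 differ in more than one place, so no step between them is drawn; their two values lie within the usual scatter of each other, and nothing is read into the difference.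

Compound 3 `CC(=O)/C(=N\c1ccc(Cl)cc1)NNc1ccccc1C` is not yet measured in this assay. It differs from compound 2 by chloro in place of hydrogen on an aromatic carbon. Among the measured compounds shown here, no step of this kind is available, so the size of the change is not anchored by a measured pair. The expectation is a step of a 1.3-fold lower number from compound 2 to compound 3 (0.12 log units; within the scatter) from compound 2, that is, no change beyond the scatter. Compound 3 is therefore estimated at 400 nM, with a range from 130 nM to 1300 nM.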

Compound 3, inhibition constant: 1830 nM
For compound 3 the middle estimate is 4.6-fold (0.66 log units) below the measured one; measured number above the stated range.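

Chloro in place of hydrogen on an aromatic carbon, para to a large group, gives the first single-place comparison in the series: in this assay the change is a 3.5-fold higher number from compound 2 to compound 3 (0.54 log units; beyond the scatter), beyond the scatter and towards a weaker inhibitor. This position on the phenyl of compound 2 is therefore not indifferent to substitution, since one added chlorine atom, with no ring, no hydrogen-bond donor or acceptor and no net charge, is enough to move the number by a modest but readable step. No supporting measurement bears on why the step goes this way, so it stands as an observation on this one pair only.

The compounds shown leave open whether the loss belongs to chloro itself or to any group at this place, and a fluoro, a methyl, a methoxy or an amine on the same aromatic carbon would separate those readings. They also leave open whether phenyl to 4-chlorophenyl gives a step of the same direction and size on the core of compound 1.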